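Aryl amine replacements on the shared core

The source may hold more compounds than are shown below. What is called first, only, known or untested is meant among the compounds shown, and "the series" means these compounds.

Measured compounds:
compound 1 `O=C1C(Nc2ccc(-c3ccc(F)cc3)cc2)=CC(=O)c2ncncc21`: 4400 nM in a functional assay on BXPC-3 cells (Homo sapiens) for cytotoxicity, read by MTT assay, with a stated time of 72 h; a lower number here means a stronger inhibitor, a higher number a weaker inhibitor
compound 2 `NC(=O)c1ccc(NC2=CC(=O)c3ncncc3C2=O)cc1`: > 10000 nM in this assay

Compound 2 gives only a limit in this assay, not a number, the value sitting at the limit of > 10000 nM in this assay, at which 1 of the 2 values shown sits. Going by the values given here, the single measured step in the set, an at least 2.2-fold higher number from compound 1 to compound 2 (0.35 log units; beyond the scatter), is the only one that touches the group on this aromatic carbon, and it shows that exchanging 4-fluorophenyl for carbamoyl moves the number past the limit.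

Compound 3 `NS(=O)(=O)c1ccc(NC2=CC(=O)c3ncncc3C2=O)cc1` differs from compound 2 by sulfamoyl in place of carbamoyl on an aromatic carbon. Among the compounds with values here, no measured step bears directly on carbamoyl against sulfamoyl; both carry one hydrogen-bond donor, and the one measured step went from a weak value to a limit. The estimated step that the limit leaves unreadable from compound 2 to compound 3 is therefore expected to be none beyond the scatter. Compound 3 is expected to give about 12000 nM, within 4000 nM to 40000 nM, and most likely to return a limit again in this assay.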

Compound 3, half-maximal inhibitory concentration: > 10000 nM
Compound 3: only a limit was reported; the forecaster's own chance of this, stated with the estimate: 65%; the middle value lies beyond the limit too.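

Compound 3 gives only a limit in this assay, as compound 2 does, so the steps that join the two limits cannot be read. Exchanging 4-fluorophenyl for sulfamoyl gives an at least 2.2-fold higher number from compound 1 to compound 3 (0.35 log units; beyond the scatter), so a second group on this aromatic carbon, not carbamoyl alone, moves the number past the limit. Compound 1 thus remains the only compound with a readable number, while carbamoyl and sulfamoyl, each with a hydrogen-bond donor, end in the same place: the limit of > 10000 nM in this assay, at which 2 of the 3 values shown sit.

Going by these compounds, how far compound 2 and compound 3 lie past the limit stays open, and with it any order between carbamoyl and sulfamoyl. Also open, on these data alone, is whether an amine, a carboxylic acid or a methoxy group on this carbon would give a readable number, or whether that takes an aryl group such as 4-fluorophenyl.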